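The source may hold more compounds than are shown below. What is called first, only, known or untested is meant among the compounds shown, and "the series" means these compounds.

Compound 1 `C=CCOc1cc(/C=C/C(=O)c2ccc(OC)c3c2OC(C)(C)C=C3)ccc1OC`: > 10000 nM
Compound 2 `COc1ccc(/C=C/C(=O)c2ccc(OC)c3c2OC(C)(C)C=C3)cc1OC(=O)C1CC1`: 220 nM

Of the compounds shown here, two have been measured in a functional assay on HepG2 cells (Homo sapiens) for cytotoxicity, read by MTT assay; on this read-out lower numbers stand for stronger inhibition and higher numbers for weaker inhibition. For compound 1 the result is only a limit of the assay, > 10000 nM, so no number is known for it. Compound 2 gives 220 nM. Among the compounds with values here, the single measured step, an at least 45-fold lower number from compound 1 to compound 2 (1.65 log units; beyond the scatter), is the only guide, and since it rests on the limit of > 10000 nM in this assay, at which 1 of the 2 values shown sits, its true size is not fixed. Compound 3 `COc1ccc(/C=C/C(=O)c2ccc(OC)c3c2OC(C)(C)C=C3)cc1OC(=O)c1ccco1` has not yet been measured. It differs from compound 1 in (furan-2-yl)carbonyl in place of allyl on an oxygen on an aromatic ring, a change of the same kind as in the measured step: in both cases a carbonyl-bearing group enters in place of allyl on an oxygen on an aromatic ring. A large fall in the number is therefore expected, an at least 25-fold lower number from compound 1 to compound 3 (1.39 log units; beyond the scatter), though the limit for compound 1 leaves its extent uncertain. Compound 3 is estimated at 400 nM, within a range from 100 nM to 5000 nM.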

Compound 3, half-maximal inhibitory concentration: 370 nM
The estimate for compound 3 lay 1.1-fold (0.03 log units) above the measured number; the range from low to high includes it.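

In this assay, a second carbonyl-bearing group on the oxygen on the aromatic ring goes with a large fall in place of allyl: an at least 27-fold lower number from compound 1 to compound 3 (1.43 log units; beyond the scatter). Compound 2 and compound 3 cannot be told apart, with furan-2-yl in place of cyclopropyl on the carbonyl carbon: a 1.7-fold higher number from compound 2 to compound 3 (0.23 log units; within the scatter). At this position, the low number is therefore not tied to cyclopropyl, and a five-membered aromatic ring on the carbonyl carbon gives a value within the scatter of it, while compound 1 is known only by a limit of the assay, so the true size of the step from it stays open: the limit of > 10000 nM in this assay, at which 1 of the 3 values shown sits.

As far as these compounds go, it remains open whether the carbonyl itself is what matters, which a benzyl group on the same oxygen would test. Also open, from the compounds shown here alone, is whether a phenyl ring or a longer chain on the carbonyl carbon would give values like those of compound 2 and compound 3.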